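Quinolinone–benzimidazole pairs: halogen swap on a second core

The compounds below may be only part of what the source reports. "The series", "measured", "known", "first", "only" and "open" are said of these compounds alone.

Measured so far in a functional assay on SK-OV-3 cells (Homo sapiens) for cytotoxicity, read by MTT assay, with a stated time of 48 h; a higher number here means a weaker inhibitor, a lower number a stronger inhibitor:
compound 1, `COc1ccc2[nH]c(=O)c(-c3nc4cc(F)ccc4[nH]3)cc2c1`, > 100000 nM
compound 2, `COc1ccc2[nH]c(=O)c(-c3nc4cc(Cl)ccc4[nH]3)cc2c1`, > 100000 nM
compound 3, `Cc1ccc2[nH]c(=O)c(-c3nc4cc(F)ccc4[nH]3)cc2c1`, > 100000 nM

Each of these three values is a limit of this assay rather than a number. For compound 1 the value given is a limit. For compound 2 the value given is likewise a limit. For compound 3 the value given is a limit as well. The shared observation is the limit of > 100000 nM in this assay, at which 3 of the 3 values shown sit.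

Compound 1 and compound 2 differ by chloro in place of fluoro on an aromatic carbon. The step that the two limits leave unreadable from compound 1 to compound 2 cannot be sized, since both ends of it are limits. Compound 1 and compound 3 differ by methyl in place of methoxy on an aromatic carbon, and the step that the two limits leave unreadable from compound 1 to compound 3 is equally unreadable for the same reason.

Not yet measured is compound 4, `Cc1ccc2[nH]c(=O)c(-c3nc4cc(Cl)ccc4[nH]3)cc2c1`. Among the measured compounds shown here, it differs from compound 3 by chloro in place of fluoro on an aromatic carbon, which is the same change as the one from compound 1 to compound 2, on the same kind of position, made on the core of compound 3 instead of the core of compound 1.

In this assay the step from compound 3 to compound 4 is expected to be a step that the limit leaves unreadable from compound 3 to compound 4, resting only on the fact that the same change between compound 1 and compound 2 moved neither compound away from the limit. Compound 4 is therefore expected to give about 150000 nM, with a plausible range from 80000 nM to 400000 nM, and most likely to be reported as a limit again.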

Compound 4, half-maximal inhibitory concentration: 33000 nM
Estimate against measurement, compound 4: 4.5-fold (0.66 log units) above; the measured number lies below the stated range.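

In this assay, among the compounds shown here, chloro in place of fluoro on the core of compound 3 gives an at least 3.0-fold lower number from compound 3 to compound 4 (0.48 log units; beyond the scatter) and, with chloro held constant, methyl in place of methoxy gives an at least 3.0-fold lower number from compound 2 to compound 4 (0.48 log units; beyond the scatter), which makes compound 4 the only one of the four compounds with a value that is not a limit. Both steps start from a limit, so each printed size is a minimum, and the chloro and methyl groups give a readable value only when present together in compound 4, while compound 2 with chloro alone and compound 3 with methyl alone do not. This does not show that the change carries from one core to another, and the steps among compounds 1, 2 and 3 cannot be read, so the same change cannot be compared on the two cores because both ends of the step on the core of compound 1 are limits: the limit of > 100000 nM in this assay, at which 3 of the 4 values shown sit.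

Going by these compounds, whether the lower number is specific to chloro remains open, and bromo or trifluoromethyl on the same aromatic carbon would address that, as would ethyl in place of methyl for the other group. For the compounds shown here, also open is whether an amine or a carboxylic acid on the shared core would move the number further, since the series so far offers a single readable value.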